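Working notes: methyl for trifluoromethyl on the shared core

The compounds below may be only part of what the source reports. "The series", "measured", "known", "first", "only" and "open" are said of these compounds alone.

Going by the values given here, compound 2 `Cc1ccc(NC(=O)NC(=O)c2ccc(OCc3ccc(C(F)(F)F)cc3)cc2)cc1-c1nc2ccccc2[nH]1` stands at the lower of the two numbers measured so far. In a functional assay on SW-620 cells (Homo sapiens) for inhibition, read by MTT assay, with a stated time of 48 h (on this read-out higher numbers stand for weaker inhibition and lower numbers for stronger inhibition), compound 2 gives 15300 nM. Among the compounds with values here, compound 1 `Cc1ccc(NC(=S)NC(=O)c2ccc(OCc3ccccc3Cl)cc2)cc1-c1nc2ccccc2[nH]1` in this assay gives 57100 nM, a higher number that lies beyond the scatter; the two compounds differ in more than one place, so no single step joins them and only the two values themselves are known. Compound 3 `Cc1ccc(COc2ccc(C(=O)NC(=O)Nc3ccc(C)c(-c4nc5ccccc5[nH]4)c3)cc2)cc1` has not been measured in this assay. It differs from compound 2 by methyl in place of trifluoromethyl on an aromatic carbon. Within the data shown here, no measured pair isolates this exchange, so nothing in hand fixes its size or direction. The expected step is small, a 1.3-fold higher number from compound 2 to compound 3 (0.12 log units; within the scatter), a change within the scatter. For compound 3 the estimated value in this assay is 20000 nM, with a range from 8000 nM to 50000 nM.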

Compound 3, half-maximal inhibitory concentration: 26000 nM
The estimate for compound 3 lay 1.3-fold (0.11 log units) below the measured number; the range from low to high includes it.
By their numbers in this assay, from the lowest: compounds 2 and 3 (each within the scatter of the next); then compound 1.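

In this assay, going by these compounds alone, the change from 4-(trifluoromethyl)benzyl to 4-methylbenzyl on the shared core gives a 1.7-fold higher number from compound 2 to compound 3 (0.23 log units; within the scatter), the only step in hand that isolates a single exchange at this position. At this place, on an aromatic carbon and para to a large group, trifluoromethyl and methyl therefore cannot be told apart on this read-out, although the exchange takes the substituent from 4 heavy atoms to 1. No supporting data bear on why this exchange reads as it does.

Still open, from the compounds shown here alone, is whether a group of another kind at this place, such as an amine, a carboxylic acid or a longer alkyl chain, would stand apart from this pair in this assay. Also open, going by these compounds, is whether the same exchange would read alike on the framework of compound 1 , which differs from compound 2 in more than one place.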